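The compounds below may be only part of what the source reports. "The series", "measured", "known", "first", "only" and "open" are said of these compounds alone.

Compound 1 `COc1ccc(-n2ccc(=O)c(C(=O)Nc3ccc(Oc4ccnc5[nH]ccc45)cc3)n2)cc1` is the starting point of the series. In a functional assay on MCF7 cells (Homo sapiens) for cytotoxicity, read by MTT assay, with a stated time of 72 h (on this read-out lower numbers stand for stronger inhibition and higher numbers for weaker inhibition), compound 1 gives 21600 nM. Compound 2 `O=C(Nc1ccc(Oc2ccnc3[nH]ccc23)cc1)c1nn(-c2ccc(Br)cc2)ccc1=O` carries a single change relative to it, (bromo in place of methoxy on an aromatic carbon), and in this assay compound 2 gives 7890 nM. The resulting step, a 2.7-fold lower number from compound 1 to compound 2 (0.44 log units; beyond the scatter), is a modest gain in potency.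

Compound 3 `COc1ccc(-n2ccc(=O)c(C(=O)Nc3ccc(Oc4ccnc5c4ccn5C)c(F)c3)n2)cc1` is built on a different core; how its core differs from that of compound 1 is not broken down here. In this assay compound 3 gives only a limit, > 60000 nM, so no number is known for it. This is the limit of > 60000 nM in this assay, at which 1 of the 3 values shown sits.

Compound 4 `Cn1ccc2c(Oc3ccc(NC(=O)c4nn(-c5ccc(Br)cc5)ccc4=O)cc3F)ccnc21` has not yet been tested. It differs from compound 3 by bromo in place of methoxy on an aromatic carbon, the same change that separates compound 1 from compound 2. The expected step is an at least 1.2-fold lower number from compound 3 to compound 4 (0.07 log units; that floor lies within the scatter), a size that rests on a 2.7-fold lower number from compound 1 to compound 2 (0.44 log units; beyond the scatter), though the starting point here is itself only a limit. Compound 4 is therefore estimated at 50000 nM, with a likely range from 15000 nM to 200000 nM.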

Compound 4, half-maximal inhibitory concentration: 33600 nM
The estimate for compound 4 lay 1.5-fold (0.17 log units) above the measured number; measured number inside the range.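

On the core of compound 3, the change from 4-methoxyphenyl to 4-bromophenyl gives an at least 1.7-fold lower number from compound 3 to compound 4 (0.25 log units; that floor lies within the scatter) in this assay, which does not contradict the direction seen on the core of compound 1, although this floor alone does not establish a gain. Going by these compounds, compound 3 has only a limit, > 60000 nM, so the full size of its step remains unknown: the limit of > 60000 nM in this assay, at which 1 of the 4 values shown sits. Set side by side, the two steps are compatible with a change that carries over between cores in direction, but they do not show that it carries over in size: the same change on two cores in this assay, a 2.7-fold lower number (0.44 log units; beyond the scatter) from compound 1 to compound 2 and an at least 1.7-fold lower number (0.25 log units; that floor lies within the scatter) from compound 3 to compound 4; the limit leaves it open whether they differ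

The compounds shown leave open whether a chloro, a trifluoromethyl or an amine in the same place on the aromatic ring would shift the number in the same direction as bromo. They also leave open how the change would behave on the core of compound 3 if the methoxy partner gave a number rather than a limit.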